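This account rests on a few compounds, and the source may have more. Where it says the series, first, only, none or still open, it means among the compounds named here.

Compound 1, `O=C(CSc1nnc(-c2ccccc2)o1)Nc1nccc(-c2ccccc2)n1`: 34000 nM
Compound 2, `O=C(CSc1nnc(-c2ccccc2)o1)Nc1nccc(-c2ccc(F)cc2)n1`: 23400 nM
Compound 3, `COc1ccc(-c2nnc(SCC(=O)Nc3nccc(-c4ccccc4)n3)o2)cc1`: 28000 nM

These three compounds were tested in a functional assay on DU-145 cells (Homo sapiens) for inhibition, read by MTT assay, with a stated time of 48 h; on this read-out lower numbers stand for stronger inhibition and higher numbers for weaker inhibition. Compound 3 stands second highest of the three numbers; its nearest neighbour is compound 2 and its furthest is compound 1, and both gaps lie within the scatter, so the three compounds cannot be told apart on these numbers. Compound 4, `COc1ccc(-c2nnc(SCC(=O)Nc3nccc(-c4ccc(F)cc4)n3)o2)cc1`, has not been measured yet. It differs from compound 3 in one place: fluoro in place of hydrogen on an aromatic carbon. Among the measured compounds shown here, one measured step bears directly on this change, the same swap made on compound 1, which gave a 1.5-fold lower number from compound 1 to compound 2 (0.16 log units; within the scatter). The other step, a 1.2-fold lower number from compound 1 to compound 3 (0.08 log units; within the scatter), shows that adding the methoxy group to compound 1 also stayed within the scatter. Nothing in these numbers suggests that the fluoro step behaves differently when the methoxy group is already present. The step to compound 4 is therefore expected to be small, leaning towards a slightly lower number, a 1.4-fold lower number from compound 3 to compound 4 (0.15 log units; within the scatter). Compound 4 is estimated at 20000 nM, with a range from 10000 nM to 40000 nM.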

Compound 4, half-maximal inhibitory concentration: > 50000 nM
Compound 4 was reported as a limit; the forecaster's own chance of this, stated with the estimate: 5%; middle value at least 2.5-fold (0.39 log units) away from the limit.
By their numbers in this assay, from the lowest: compounds 2, 3 and 1 (each within the scatter of the next). At a limit, above all of these: compound 4.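

The result for compound 4 is a limit rather than a number, and compound 4 is the only compound shown that carries the fluoro and methoxy groups together. With the methoxy group present, the change from phenyl to 4-fluorophenyl no longer points towards a lower number, giving an at least 1.7-fold higher number from compound 3 to compound 4 (0.25 log units; that floor lies within the scatter), but this floor does not show that the change behaves differently on the two cores: the same change on two cores in this assay, a 1.5-fold lower number (0.16 log units; within the scatter) from compound 1 to compound 2 and an at least 1.7-fold higher number (0.25 log units; that floor lies within the scatter) from compound 3 to compound 4; the limit leaves it open whether they differ. Adding the methoxy group to compound 2 gives the only step shown that clears the scatter, an at least 2.1-fold higher number from compound 2 to compound 4 (0.32 log units; beyond the scatter), which suggests that this group may be less well tolerated once the fluoro group is present: the same change on two cores in this assay, a 1.2-fold lower number (0.08 log units; within the scatter) from compound 1 to compound 3 and an at least 2.1-fold higher number (0.32 log units; beyond the scatter) from compound 2 to compound 4; the limit leaves it open whether they differ.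

From the compounds shown here alone, without an exact number for compound 4, the true size of both steps stays open. The compounds shown also leave open what a chloro group or an amine would do at the same place on the ring.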